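The compounds below may be only part of what the source reports. "The series", "measured", "known", "first", "only" and "open" are said of these compounds alone.

In a functional assay on A549 cells (Homo sapiens) for inhibition, with a stated time of 72 h (on this read-out lower numbers stand for stronger inhibition and higher numbers for weaker inhibition), compound 3 `O=C(Nc1ccccc1)Nc1nc(Sc2c[nH]c3ccccc23)cc(N2CCCC2)n1` gives 21200 nM, the highest of the two numbers shown. Compound 2 `O=C(Nc1ccc(Cl)cc1)Nc1nc(Sc2c[nH]c3ccccc23)cc(N2CCCC2)n1` gives 6410 nM. Compound 1 `O=C(Nc1ccccc1)Nc1nc(NC2CC2)cc(Sc2c[nH]c3ccccc23)n1` reaches only a limit of the assay, > 50000 nM. Compound 4 `O=C(Nc1ccccc1)Nc1nc(Nc2ccccc2)cc(Sc2c[nH]c3ccccc23)n1` differs from compound 3 by anilino in place of pyrrolidin-1-yl on an aromatic carbon. Within the data shown here, two measured steps touch this position or this series: a 3.3-fold higher number from compound 2 to compound 3 (0.52 log units; beyond the scatter), which concerns the other end of the molecule, and an at least 2.3-fold lower number from compound 1 to compound 3 (0.37 log units; beyond the scatter), which exchanged the group at this very carbon. Because the earlier exchange an at least 2.3-fold lower number from compound 1 to compound 3 (0.37 log units; beyond the scatter) moved from a nitrogen-linked group toward pyrrolidin-1-yl and the new change moves back to a nitrogen-linked anilino, a step toward a higher number is expected, about a 1.4-fold higher number from compound 3 to compound 4 (0.15 log units; within the scatter). Compound 4 is therefore estimated at 30000 nM, within 8000 nM to 100000 nM, with a real chance that only a limit is reported.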

Compound 4, half-maximal inhibitory concentration: > 50000 nM
Compound 4 gave a limit, no number; the forecaster's own chance of this, stated with the estimate: 35%; middle value at least 1.6-fold (0.22 log units) away from the limit.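

The change to anilino gives an at least 2.3-fold higher number from compound 3 to compound 4 (0.37 log units; beyond the scatter), so a nitrogen-linked aromatic ring on this carbon does not keep the activity seen with pyrrolidin-1-yl. Of the three groups shown here, only pyrrolidin-1-yl gives a number. The step between compound 1 and compound 4 cannot be read because both values are limits: the limit of > 50000 nM in this assay, at which 2 of the 4 values shown sit.

The compounds shown leave open whether another saturated ring amine on this carbon, such as piperidin-1-yl or morpholin-4-yl, also gives a number. Also open, on these data alone, is whether the chloro group of compound 2 would bring the anilino compound within range.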